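Halogen swap on the benzyl ring of the series

The source may hold more compounds than are shown below. What is called first, only, known or untested is meant among the compounds shown, and "the series" means these compounds.

Of the compounds shown here, two carry numbers so far. Compound 1 `O=c1cc(CN(c2cccc(Cl)c2)c2ccncn2)c2ccc(F)c(F)c2[nH]1` gives 14 nM in an assay on HEK293 cells for inhibition of Nitric oxide synthase, inducible (Homo sapiens), read by fluorescence; a lower number here means a stronger inhibitor, a higher number a weaker inhibitor. Compound 2 `O=c1cc(CN(Cc2ccccc2Cl)c2cnccn2)c2ccc(F)c(F)c2[nH]1` gives 12 nM in this assay; this is the lower of the two numbers, but the gap to compound 1 lies within the scatter, so the two stand level. Among the compounds with values here, no step between measured compounds that differ in one place is available.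

Compound 3 `O=c1cc(CN(Cc2ccccc2F)c2cnccn2)c2ccc(F)c(F)c2[nH]1` is not yet measured. It differs from compound 2 by fluoro in place of chloro on an aromatic carbon. With no measured step of this kind in the series, the expectation rests on the change alone: one halogen for another, expected to move the number little, with a slight drift toward a higher number as the more likely direction. The step from compound 2 to compound 3 is estimated at a 1.7-fold higher number from compound 2 to compound 3 (0.22 log units; within the scatter). For compound 3 the estimate in this assay is 20 nM, with a range from 8 nM to 50 nM.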

Compound 3, half-maximal inhibitory concentration: 12 nM
For compound 3 the middle estimate is 1.7-fold (0.22 log units) above the measured one; measured number inside the range.
By their numbers in this assay, from the lowest: compounds 2, 3 and 1 (each within the scatter of the next).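

In this assay, within the data shown here, replacing 2-chlorobenzyl with 2-fluorobenzyl gives no change at the digits printed from compound 2 to compound 3 (within the scatter), the first step that can be read at a single place. At this aromatic carbon of the benzyl ring, chloro is therefore not needed to hold the number, since fluoro stands level with it in this one pair. No measurement available bears on why the two halogens read alike.

The compounds shown leave open whether this place accepts anything other than a halogen, such as a methoxy group, a nitrile or an amine, or whether plain hydrogen would do as well. They also leave open whether the same halogen swap would read alike on the structure of compound 1, where the rest of the molecule differs.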